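A furan-2-yl group enters the shared core

This account rests on a few compounds, and the source may have more. Where it says the series, first, only, none or still open, it means among the compounds named here.

In a functional assay on A549 cells (Homo sapiens) for antiproliferative activity, read by MTT assay, with a stated time of 48 h (a lower number here means a stronger inhibitor, a higher number a weaker inhibitor), three compounds built on one core have been measured. Compound 1 `COc1ccc(-c2nc3cccc(-c4cc(OC)c(OC)c(OC)c4)c3o2)cc1OC` gives 2800 nM, compound 2 `COc1cc(-c2cccc3nc(-c4cccc(C)c4)oc23)cc(OC)c1OC` gives 16700 nM and compound 3 `COc1cc(-c2nc3cccc(-c4cc(OC)c(OC)c(OC)c4)c3o2)ccc1O` gives 15700 nM. The step of a 1.1-fold lower number from compound 2 to compound 3 (0.03 log units; within the scatter) lies within the scatter, while the step of a 5.6-fold higher number from compound 1 to compound 3 (0.75 log units; beyond the scatter) lies beyond it. Compound 3 therefore stands with compound 2, and compound 1 is the most potent of the three.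

Compound 4 `COc1cc(-c2cccc3nc(-c4ccco4)oc23)cc(OC)c1OC` carries furan-2-yl in place of 4-hydroxy-3-methoxyphenyl on an aromatic carbon of a five-membered aromatic ring with 1 nitrogen and 1 oxygen (furan-2-yl in place of 4-hydroxy-3-methoxyphenyl on an aromatic carbon). The closest guides are the earlier changes at this same place. Putting 3-methylphenyl in place of 3,4-dimethoxyphenyl gave a modest step, a 6.0-fold higher number from compound 1 to compound 2 (0.78 log units; beyond the scatter). Exchanging 3-methylphenyl for 4-hydroxy-3-methoxyphenyl gave no change beyond the scatter, a 1.1-fold lower number from compound 2 to compound 3 (0.03 log units; within the scatter). For the measured compounds named here, no compound with a five-membered ring at this place has been measured, so the guidance is indirect. With two different groups already giving matching values in compound 2 and compound 3, no clear shift is expected. The expected change is a 1.1-fold lower number from compound 3 to compound 4 (0.05 log units; within the scatter), with no step beyond the scatter foreseen. Compound 4 is estimated at 14000 nM, with an expected range from 5000 nM to 40000 nM.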

Compound 4, half-maximal inhibitory concentration: 10300 nM
Estimate against measurement, compound 4: 1.4-fold (0.13 log units) above, within the range that was stated.
By their numbers in this assay, from the lowest: compound 1; then compounds 4, 3 and 2 (each within the scatter of the next).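

In this assay, the place on the five-membered aromatic ring with 1 nitrogen and 1 oxygen now holds its first five-membered group, and furan-2-yl, with fewer heavy atoms and no hydrogen-bond donor, gives a 1.5-fold lower number from compound 3 to compound 4 (0.18 log units; within the scatter) and a 1.6-fold lower number from compound 2 to compound 4 (0.21 log units; within the scatter), both within the scatter. Compounds 2, 3 and 4 thus form one group of matching values across 3-methylphenyl, 4-hydroxy-3-methoxyphenyl and furan-2-yl, so among these three neither ring size nor the presence of a hydrogen-bond donor separates the values, while 3,4-dimethoxyphenyl stands apart with a 3.7-fold higher number from compound 1 to compound 4 (0.57 log units; beyond the scatter), a modest step beyond the scatter. Nothing at hand explains why these three groups match or why compound 1 stands apart.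

The compounds shown leave open whether an amine, a carboxylic acid or a longer alkyl chain at this place would stay with compounds 2, 3 and 4 or come closer to compound 1. They also leave open whether adding methoxy groups to the furan-2-yl ring would move its value toward that of compound 1, as the second methoxy group of 3,4-dimethoxyphenyl might suggest.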